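Ester-bearing anilides in a kinase series: from compound 2 to compound 4

A few compounds are considered here, and "the series" means these few. Any claim that something is new, unique, unknown or untested is made for them only; others in the source may bear on it.

Three measured compounds share a core and differ in the aryl group on the amide nitrogen. Compound 1 `COCCOC(=O)c1ccc(F)c(C(=O)Nc2cccc(-c3cc(C(=O)Nc4ccncc4F)ccc3CN)c2)c1` is measured in an assay on cells for inhibition of Rho-associated protein kinase 2 (Homo sapiens), read by radiometric assay and 33P incorporation, in the presence of a further agent that is not named here (on this read-out higher numbers stand for weaker inhibition and lower numbers for stronger inhibition), and its value of < 1 nM is a limit of the assay rather than a number. Compound 3 `NCc1ccc(C(=O)Nc2ccncc2F)cc1-c1cccc(NC(=O)c2ccc(C(=O)O)cc2)c1` gives 1 nM in this assay. Compound 2 `CCCOC(=O)c1ccc(NC(=O)c2cccc(-c3cc(C(=O)Nc4ccncc4F)ccc3CN)c2)cc1` also reaches only a limit in this assay, namely < 1 nM. Compound 2 therefore stands at the floor of what the assay reports, together with compound 1, as the limit of < 1 nM in this assay, at which 2 of the 3 values shown sit, records; compound 3 sits within the usual scatter of that region.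

Compound 4 `COC(=O)c1cccc(NC(=O)c2cccc(-c3cc(C(=O)Nc4ccncc4F)ccc3CN)c2)c1F` is not yet measured. It arises from compound 2 by the change 2-fluoro-3-(methoxycarbonyl)phenyl in place of 4-(propoxycarbonyl)phenyl on an amide-type nitrogen. Among the measured compounds shown here, no measured pair of this series describes such a step, so no direction can be read off, and the step of an at least 1.2-fold higher number from compound 2 to compound 4 (0.07 log units; that floor lies within the scatter) is expected to stay within the scatter. Compound 4 is accordingly estimated at 1.2 nM in this assay, with a range from 0.3 nM to 5 nM.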

Compound 4, half-maximal inhibitory concentration: 1.2 nM
Compound 4: the middle estimate sits on the measured number at the digits printed; the measured number falls inside the stated range.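

Among the compounds shown here, exchanging 4-(propoxycarbonyl)phenyl for 2-fluoro-3-(methoxycarbonyl)phenyl on an amide-type nitrogen gives, in this assay, an at least 1.2-fold higher number from compound 2 to compound 4 (0.07 log units; that floor lies within the scatter), the first step that can be read at this place. It shows that a phenyl ester carrying fluorine and a methyl ester in place of the propyl ester still keeps compound 4 in the same low region of the read-out. The step remains only a floor, and its full size cannot be stated, because compound 2 carries a limit and not a number: the limit of < 1 nM in this assay, at which 2 of the 4 values shown sit.

The fluorine and the change of ester arrive together in this step, so the compounds shown do not separate them. They also leave open how an amine or a longer chain in place of the ester would read in this assay.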